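The compounds below may be only part of what the source reports. "The series", "measured", "known", "first", "only" and "open" are said of these compounds alone.

Working notes on the aryl urea series in an assay on HEK293 cells for inhibition of transient receptor potential cation channel subfamily V member 1 (Homo sapiens), read by FLIPR, at pH 5.5; on this read-out lower numbers stand for stronger inhibition and higher numbers for weaker inhibition.

Among the compounds with values here, compound 3 `Cc1cnnc(N2CCN(C(=O)Nc3ccc(C(C)C)cc3)CC2)c1` is the one member of the set that returns a number: in this assay compound 3 gives 20300 nM. Compound 1 `Cc1ccc(N2CCN(C(=O)Nc3ccc(OC(F)(F)F)cc3)CC2)nn1` stops at a limit of the assay, for in this assay compound 1 gives > 10000 nM. Compound 2 `Cc1cc(N2CCN(C(=O)Nc3ccc(OC(F)(F)F)cc3)CC2)nnc1Cl` likewise stops at a limit, since in this assay compound 2 gives > 10000 nM. The step that the two limits leave unreadable from compound 1 to compound 2 therefore cannot be read. Taken together, the limit of > 10000 nM in this assay, at which 2 of the 3 values shown sit, marks where most of the set sits, and compound 3 stands only a little beyond it on the weak side.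

Compound 4 `Cc1cnnc(N2CCN(C(=O)Nc3ccc(OC(F)(F)F)cc3)CC2)c1` is not yet measured. Its change from compound 3 is trifluoromethoxy in place of isopropyl on an aromatic carbon. Within the data shown here, no measured pair differs in exactly this place, so no step bears on it directly; the only bearing is that compound 1 and compound 2, which both carry the trifluoromethoxy group entering here, sit at the limit. Compound 3 with isopropyl, by contrast, gives 20300 nM in this assay. Compound 4 is therefore expected to stay in the weak region, with a step of a 1.4-fold lower number from compound 3 to compound 4 (0.13 log units; within the scatter) that need not exceed the scatter. The estimate for compound 4 in this assay is 15000 nM, in the range 5000 nM to 50000 nM, and a limit rather than a number is a real possibility.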

Compound 4, half-maximal inhibitory concentration: > 10000 nM
Compound 4: a limit, no number (the forecaster's own chance of this, stated with the estimate: 60%); the middle value lies beyond the limit too.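

Compound 4 gives > 10000 nM in this assay, which is a limit and not a number, so the steps to it from compound 1, compound 2 and compound 3 cannot be read. The compounds shown leave open whether any of these changes moves inhibition at all, with most of the set sitting at one value: the limit of > 10000 nM in this assay, at which 3 of the 4 values shown sit.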